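Ester-Bearing Replacement of Bromo in the Aminochromone Series

This account rests on a few compounds, and the source may have more. Where it says the series, first, only, none or still open, it means among the compounds named here.

Compound 2 `Nc1ccc(-c2cc(=O)c3c(N)c(F)c(Br)c(F)c3o2)cc1F` gives 160 nM in a functional assay on MCF7 cells (Homo sapiens) for cytotoxicity, read by neutral red uptake, with a stated time of 3 days; a higher number here means a weaker inhibitor, a lower number a stronger inhibitor. Compound 1 `CCc1c(F)c(N)c2c(=O)cc(-c3ccc(N)c(F)c3)oc2c1F` gives 130 nM in this assay, and the step of a 1.2-fold higher number from compound 1 to compound 2 (0.09 log units; within the scatter) places compound 2 as the higher of the two numbers, though the two values lie within the scatter of each other. Compound 3 `Nc1ccc(-c2cc(=O)c3c(N)c(F)c(C(=O)O)c(F)c3o2)cc1F` reaches only a limit of the assay, > 10000 nM, in this assay, as noted in the limit of > 10000 nM in this assay, at which 1 of the 3 values shown sits.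

Compound 4 `CN(C)CCCC(=O)OCc1c(F)c(N)c2c(=O)cc(-c3ccc(N)c(F)c3)oc2c1F` is not yet measured. It differs from compound 2 as follows: (((3-(dimethylamino)propyl)carbonyl)oxy)methyl in place of bromo on an aromatic carbon.

Within the data shown here, two measured steps bear on this change. The swap of ethyl for bromo, a 1.2-fold higher number from compound 1 to compound 2 (0.09 log units; within the scatter), left the number essentially unchanged. The swap of bromo for carboxy, an at least 62-fold higher number from compound 2 to compound 3 (1.79 log units; beyond the scatter), caused a large loss, and the comparable step an at least 76-fold higher number from compound 1 to compound 3 (1.88 log units; beyond the scatter) confirms that the carboxy group is poorly tolerated at this carbon. Among the measured compounds shown here, the entering group in compound 4 is not a carboxy but a larger ester-linked chain, so the outcome is uncertain; the series offers no direct precedent for a substituent of this size at this position.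

The expectation for compound 4 is a modest weakening, a 2.5-fold higher number from compound 2 to compound 4 (0.40 log units; beyond the scatter), with the estimate at 400 nM and a range from 120 nM to 2500 nM.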

Compound 4, half-maximal inhibitory concentration: 29 nM
Estimate against measurement, compound 4: 14-fold (1.14 log units) above; the whole stated range lies above it.
By their numbers in this assay, from the lowest: compound 4; then compounds 1 and 2 (each within the scatter of the next). At a limit, above all of these: compound 3.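

In this assay, the carbon ortho to two fluoro groups accepts far more than a single heavy atom: (((3-(dimethylamino)propyl)carbonyl)oxy)methyl, with 10 heavy atoms in place of the 1 of bromo, gives a 5.5-fold lower number from compound 2 to compound 4 (0.74 log units; beyond the scatter), and extending the ethyl group of compound 1 to this chain gives a 4.5-fold lower number from compound 1 to compound 4 (0.65 log units; beyond the scatter). The earlier loss with carboxy therefore does not extend to every oxygen-bearing group at this carbon, as the ester-linked chain differs from carboxy by an at least 340-fold lower number from compound 3 to compound 4 (2.53 log units; beyond the scatter). That last step starts from a limit of the assay and not from a number: the limit of > 10000 nM in this assay, at which 1 of the 4 values shown sits.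

The compounds shown do not separate the contribution of the ester link from that of the terminal dimethylamino group; a matching amide, a chain ending in a primary amine, or a plain longer alkyl chain at this carbon would address that. On these data alone, all four values also come from this assay, so whether their order holds in other cell lines remains open.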